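The compounds below may be only part of what the source reports. "The series", "measured", "known", "first", "only" and "open" are said of these compounds alone.

The series shares the core of compound 1 `O=[N+]([O-])c1ccc(CN2CCC(n3cc(CC(OCc4cc(-c5ccc(F)cc5)no4)c4ccc(Br)cc4)nn3)CC2)cc1`. In an ADME assay on cells (Fibroblast, Homo sapiens) for cytotoxicity, with a stated time of 48 h (a lower number here means a stronger inhibitor, a higher number a weaker inhibitor), compound 1 gives > 25000 nM, which is a limit of the assay and not a number. Compound 2 `O=[N+]([O-])c1ccc(CN2CCC(n3cc(CC(OCc4cc(-c5cccc(Br)c5)no4)c4ccc(Br)cc4)nn3)CC2)cc1` gives in this assay > 25000 nM, also a limit. The step from compound 1 to compound 2, a step that the two limits leave unreadable from compound 1 to compound 2, stays unreadable because of the limit of > 25000 nM in this assay, at which 2 of the 2 values shown sit. Compound 2 therefore stands only at a limit, with no number to anchor it. Compound 3 `O=[N+]([O-])c1ccc(CN2CCC(n3cc(CC(OCc4cc(-c5cccc(F)c5)no4)c4ccc(Br)cc4)nn3)CC2)cc1` differs by fluoro in place of bromo on an aromatic carbon. No readable measured step bears on this change, so no step beyond the scatter is expected, the step from compound 2 to compound 3 being estimated as a number no higher from compound 2 to compound 3 (the limit leaves the size open). Compound 3 is expected at 25000 nM, with a range of 10000 nM to 80000 nM.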

Compound 3, half-maximal inhibitory concentration: 10000 nM
Compound 3: middle estimate off by 2.5-fold (0.40 log units), on the high side; the range from low to high includes it.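

Compound 3 is the only compound shown in this assay with a number and not a limit, so this position now has a readable direction: fluoro in place of bromo gives an at least 2.5-fold lower number from compound 2 to compound 3 (0.39 log units; beyond the scatter). The placing of the fluoro also matters, as 3-fluorophenyl in place of 4-fluorophenyl gives an at least 2.5-fold lower number from compound 1 to compound 3 (0.39 log units; beyond the scatter). Both steps are bounds and not exact sizes, and the step between the other two compounds cannot be read: the limit of > 25000 nM in this assay, at which 2 of the 3 values shown sit.

On these data alone, whether an amine or a methoxy group on the same aromatic carbon would shift the number further in this assay stays open.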